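A few compounds are considered here, and "the series" means these few. Any claim that something is new, unique, unknown or untested is made for them only; others in the source may bear on it.

Compound 1, `Cc1cc(C)c(NC(=O)N(Cc2c[nH]c(-c3ccccc3)n2)C2CCCCCC2)c(C)c1`: in a functional assay on a cell-free system (plasma) with sterol O-acyltransferase, Soat (Rattus norvegicus) as the target (a higher number here means that more compound is needed for the effect, a lower number that less compound is needed), compound 1 reaches only a limit of the assay, > 1 mg/kg.
Compound 2, `O=C(Nc1c(F)cc(F)cc1F)N(Cc1ccc(-c2cccs2)cc1)C1CCCCCC1`: in this assay compound 2 likewise stops at a limit, > 1 mg/kg.
Compound 3, `O=C(Nc1c(F)cc(F)cc1F)N(Cc1cccc(-c2cc[nH]n2)c1)C1CCCCCC1`: in this assay compound 3 gives 0.062 mg/kg.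

Within the data shown here, compound 3 therefore stands alone as the one compound with an actual number in this assay; the two others sit at the limit of > 1 mg/kg in this assay, at which 2 of the 3 values shown sit, so no measured step between compounds can be computed, and no ordering among them beyond that can be stated.

Compound 4, `O=C(Nc1c(F)cc(F)cc1F)N(Cc1ccc(F)cc1)Cc1cccc(-c2cc[nH]n2)c1`, has not yet been measured. It differs from compound 3 in one place: 4-fluorobenzyl in place of cycloheptyl on an amide-type nitrogen. Among the measured compounds shown here, since no pair of measured compounds shows what exchanging the cycloheptyl for a 4-fluorobenzyl group does on this nitrogen, there is no measured step to lean on. The account expects the change to cost something, a step from compound 3 to compound 4 of a 2.9-fold higher number from compound 3 to compound 4 (0.46 log units; beyond the scatter) in this assay, with a real chance that compound 4 ends at a limit. For compound 4 the estimate in this assay is 0.18 mg/kg, with a range from 0.05 mg/kg to 0.7 mg/kg.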

Compound 4, dose for half-maximal effect: < 0.32 mg/kg
Compound 4 ended at the assay's limit; the forecaster's own chance of this, stated with the estimate: 25%; the middle value does not contradict the limit.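

In this assay compound 4 reaches only a limit of the assay, < 0.32 mg/kg. The step from compound 3 to compound 4 cannot be read from this limit, and the exchange of cycloheptyl for 4-fluorobenzyl has no measured size. The compounds shown leave open where compound 4 actually lies relative to compound 3, including the direction of any difference.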